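The source may report more compounds than this note shows. Statements on the series, on what has been measured and on what is new or still open speak of the compounds shown alone.

Measured so far:
- compound 1 `COc1cc(/C=C/C(=O)c2cccc(-n3cc(-c4ccccc4)[nH]c3=O)c2)ccc1O`: 2110 nM
- compound 2 `O=C(/C=C/c1cccc(O)c1)c1cccc(-n2cc(-c3ccc(Cl)cc3)[nH]c2=O)c1`: 580 nM

Of the compounds shown here, two have been measured in a functional assay on U-251 cells (Homo sapiens) for inhibition; on this read-out higher numbers stand for weaker inhibition of growth and lower numbers for stronger inhibition of growth. Compound 1 `COc1cc(/C=C/C(=O)c2cccc(-n3cc(-c4ccccc4)[nH]c3=O)c2)ccc1O` gives 2110 nM. Compound 2 `O=C(/C=C/c1cccc(O)c1)c1cccc(-n2cc(-c3ccc(Cl)cc3)[nH]c2=O)c1` gives 580 nM, the lowest number of the two and beyond the scatter from compound 1. The two differ in more than one place, so the numbers are taken as they stand without assigning the gap to either change.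

The next compound, compound 3 `O=C(/C=C/c1cccc(O)c1)c1cccc(-n2cc(-c3ccccc3)[nH]c2=O)c1`, is not yet measured in this assay. It differs from compound 2 in one place: hydrogen in place of chloro on an aromatic carbon. Going by the values given here, no single-change step of this kind has been measured, so the direction rests on compound 2 alone. For compound 3 a moderate move toward a higher number is expected, a 2.1-fold higher number from compound 2 to compound 3 (0.32 log units; beyond the scatter), with the possibility that it stays within the scatter of compound 2. The estimate for compound 3 is 1200 nM, with a range of 500 nM to 3000 nM.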

Compound 3, concentration for 50% growth inhibition: 1610 nM
Beside the measured number, compound 3's estimate is 1.3-fold (0.13 log units) below it, within the range that was stated.
By their numbers in this assay, from the lowest: compound 2; then compounds 3 and 1 (each within the scatter of the next).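

Working in this assay, the series now has its first single-change reading at the position para to a large group on the six-membered aromatic ring: 4-chlorophenyl to phenyl gives a 2.8-fold higher number from compound 2 to compound 3 (0.44 log units; beyond the scatter) and is beyond the scatter, so at this place the chloro goes with stronger inhibition of growth than hydrogen. The other step, 3-hydroxyphenyl in place of 4-hydroxy-3-methoxyphenyl, gives a 1.3-fold lower number from compound 1 to compound 3 (0.12 log units; within the scatter) and stays within the scatter, so with an unsubstituted phenyl this change does not separate the two compounds. Nothing available explains the chloro step.

As far as these compounds go, whether fluoro, bromo, methoxy, trifluoromethyl or an amine at the same place would match or pass chloro remains open. Also open, from the compounds shown here alone, is whether the chloro step carries over to compounds bearing the 4-hydroxy-3-methoxyphenyl group.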